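This account rests on a few compounds, and the source may have more. Where it says the series, first, only, none or still open, it means among the compounds named here.

In a functional assay on DU-145 cells (Homo sapiens) for inhibition, read by trypan blue exclusion, with a stated time of 96 h (on this read-out higher numbers stand for weaker inhibition of growth and lower numbers for stronger inhibition of growth), compound 3 (`Cc1ccc(S(=O)(=O)/C(=C/c2ccccc2OCc2ccccc2)C(=O)c2ccc(Br)cc2)cc1`) gives 1000 nM, level with compound 1 (`COc1ccccc1/C=C(\C(=O)c1ccc(Br)cc1)S(=O)(=O)c1ccc(C)cc1`) at 1000 nM, while compound 2 (`O=C(/C(=C\c1ccc(Cl)cc1)SCc1ccc(Cl)cc1)c1ccc(Br)cc1`) stands at the higher number of 10000 nM. Compound 4 (`O=C(/C(=C\c1ccccc1OCc1ccccc1)S(=O)(=O)Cc1ccc(Cl)cc1)c1ccc(Br)cc1`) carries 4-chlorobenzyl in place of 4-methylphenyl on a sulfonyl sulfur. Among the measured compounds shown here, the one measured single-place step, no change at the digits printed from compound 1 to compound 3 (within the scatter), is a change of phenyl in place of hydrogen on a saturated chain carbon bound to an oxygen on an aromatic ring. It lies at a different place and says nothing directly about the group on sulfur. Compound 2, at 10000 nM, also holds a 4-chlorobenzyl group, but it differs from compound 3 in more than one place, so it supports only a slight expected lean towards a higher number in this assay. For the measured compounds named here, no measured pair isolates this change, and the range stays wide. The expected shift is a 2.0-fold higher number from compound 3 to compound 4 (0.30 log units; within the scatter), close to the edge of the usual scatter. The estimate for compound 4 is 2000 nM, with an expected range of 500 nM to 8000 nM.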

Compound 4, concentration for 50% growth inhibition: 10000 nM
Compound 4: middle estimate off by 5.0-fold (0.70 log units), on the low side; the measured number lies above the stated range.
By their numbers in this assay, from the lowest: compounds 1 and 3 (each within the scatter of the next); then compounds 2 and 4 (each within the scatter of the next).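

In this assay, putting 4-chlorobenzyl in place of 4-methylphenyl on a sulfonyl sulfur gives a 10-fold higher number from compound 3 to compound 4 (1.00 log units; beyond the scatter). Among the compounds shown here, this is the first measured change at this place, and it shows that the group on the sulfonyl sulfur affects the read-out, whereas the only earlier step, no change at the digits printed from compound 1 to compound 3 (within the scatter), at a different place, did not move the number beyond the scatter. Nothing available explains the weaker inhibition of growth with 4-chlorobenzyl at this place.

The step swaps methyl for chlorine on the ring and also adds a chain carbon between the ring and sulfur, and the compounds shown do not separate these two changes. Plain benzyl or 4-chlorophenyl on the same sulfonyl sulfur would pull them apart, and how an amine or a carboxylic acid on that ring would read remains open.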